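A few compounds are considered here, and "the series" means these few. Any claim that something is new, unique, unknown or untested is made for them only; others in the source may bear on it.

The three measured compounds share one core and differ only in the group carried by the piperazine nitrogen. Compound 1 `O=C(CN1CCN(c2ccccc2F)CC1)Nc1ccc(C(=O)/C=C/c2cn(Cc3ccc(Br)cc3)nn2)cc1` gives 11300 nM in a functional assay on MCF7 cells (Homo sapiens) for inhibition, read by MTT assay; on this read-out higher numbers stand for weaker inhibition and lower numbers for stronger inhibition. Compound 2 `O=C(CN1CCN(c2ccccc2)CC1)Nc1ccc(C(=O)/C=C/c2cn(Cc3ccc(Br)cc3)nn2)cc1`, which carries a phenyl in place of the 2-fluorophenyl, gives 49200 nM in this assay, the highest number of the three; compound 3 `O=C(CN1CCN(c2ccc([N+](=O)[O-])cc2)CC1)Nc1ccc(C(=O)/C=C/c2cn(Cc3ccc(Br)cc3)nn2)cc1` gives 31600 nM. The step of a 4.4-fold higher number from compound 1 to compound 2 (0.64 log units; beyond the scatter) lies beyond the scatter, as does a 2.8-fold higher number from compound 1 to compound 3 (0.45 log units; beyond the scatter), whereas compounds 2 and 3 sit within the scatter of each other, so no order between them can be claimed.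

Compound 4 `O=C(CBr)Nc1ccc(C(=O)/C=C/c2cn(Cc3ccc(Br)cc3)nn2)cc1` departs from this pattern by a different kind of change: bromo in place of 4-phenylpiperazin-1-yl on a saturated chain carbon bound to a carbonyl carbon. Within the data shown here, none of the measured steps touches this position; they only exchange the aryl on the piperazine, and those exchanges moved the number by modest amounts. The measured steps therefore give no direct guide to the size or direction of the change from compound 2 to compound 4, and the expectation for compound 4 must be held loosely, allowing for a wide range around the numbers seen so far. On that basis the number for compound 4 is expected to be 15000 nM, with a range from 3000 nM to 70000 nM, which would mean an estimated step of a 3.3-fold lower number from compound 2 to compound 4 (0.52 log units; beyond the scatter).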

Compound 4, half-maximal inhibitory concentration: 10100 nM
Estimate against measurement, compound 4: 1.5-fold (0.17 log units) above; the measured number falls inside the stated range.
By their numbers in this assay, from the lowest: compounds 4 and 1 (each within the scatter of the next); then compounds 3 and 2 (each within the scatter of the next).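

Among these compounds, the step of a 4.9-fold lower number from compound 2 to compound 4 (0.69 log units; beyond the scatter) in this assay is the first change at the saturated chain carbon bound to a carbonyl carbon, a position the aryl exchanges on the piperazine never touched. It shows that the whole 4-phenylpiperazin-1-yl, with its 12 heavy atoms and two rings, can give way to a single bromo and the number still falls beyond the scatter, so among these compounds neither the piperazine nor its aryl is needed for a number at this level: compound 4 gives 10100 nM and sits within the scatter of compound 1 at 11300 nM. No measurement at hand offers a reason for this step.

On these data alone, what a chloro, a hydrogen or a dimethylamino group would give on this carbon remains open, and with it whether the step belongs to the bromo itself or to the departure of the 4-phenylpiperazin-1-yl. Equally open, as far as these compounds go, is whether a longer chain carrying the bromo, or a morpholine in place of the piperazine, would hold the number at this level.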